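A Bulkier Group on a Barely Toxic Compound

This account rests on a few compounds, and the source may have more. Where it says the series, first, only, none or still open, it means among the compounds named here.

compound 1 `Cc1cc(NC(=O)Nc2cccc(C(F)(F)F)c2)c2ccccc2n1`: 21000 nM
compound 2 `Cc1cc(NC(=O)Nc2ccc([N+](=O)[O-])c(C(F)(F)F)c2)c2ccccc2n1`: > 25000 nM (a limit)
compound 3 `Cc1cc(NC(=O)Nc2cccc(C(C)(C)C)c2)c2ccccc2n1`: not yet measured

Within the data shown here, in an ADME assay on HepG2 cells (Homo sapiens) for cytotoxicity, with a stated time of 72 h (on this read-out lower numbers stand for an effect already at smaller amounts and higher numbers for an effect only at larger amounts of compound), compound 1 gives the only actual number, 21000 nM. Compound 2 gives only a limit, > 25000 nM.

Compound 3 differs from compound 1 by a single change, tert-butyl in place of trifluoromethyl on an aromatic carbon.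

Among the measured compounds shown here, only one measured step exists, an at least 1.1-fold higher number from compound 1 to compound 2 (0.07 log units; that floor lies within the scatter). It is a different change, nitro in place of hydrogen on an aromatic carbon, so it offers only weak guidance. With compound 1 at 21000 nM as the sole anchor, a value close to it is expected, with no clear direction.

The estimated step is a 1.2-fold lower number from compound 1 to compound 3 (0.09 log units; within the scatter), and no move beyond the scatter is expected. The nearby ceiling is the limit of > 25000 nM in this assay, at which 1 of the 2 values shown sits, and an expected result could also end there. For compound 3 the expected value is 17000 nM, with an estimated range from 8000 nM to 25000 nM.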

Compound 3, half-maximal effective concentration: > 25000 nM
Compound 3 was reported as a limit; the forecaster's own chance of this, stated with the estimate: 30%; middle value at least 1.4-fold (0.16 log units) away from the limit.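

In this assay, tert-butyl in place of trifluoromethyl on this aromatic carbon gives an at least 1.1-fold higher number from compound 1 to compound 3 (0.07 log units; that floor lies within the scatter). Compound 3 gives > 25000 nM, which is a limit and not a number. This is the first change shown at this position itself, and swapping the fluorine-bearing group for an all-carbon group with the same count of heavy atoms gives no sign of an effect at smaller amounts, though the true size of the step stays hidden because the values gather at the top of the tested range: the limit of > 25000 nM in this assay, at which 2 of the 3 values shown sit.

As far as these compounds go, whether a different group here, such as an amine or a carboxylic acid, would bring the effect to clearly smaller amounts remains open. Also open, from the compounds shown here alone, is whether tert-butyl would behave the same way with the nitro group of compound 2 on the ring.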